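A few compounds are considered here, and "the series" means these few. Any claim that something is new, unique, unknown or untested is made for them only; others in the source may bear on it.

Measured compounds:
- compound 1 `CC(C)N(Cc1cccc(OCCCCCC(=O)O)c1)C(=O)c1ccc(-c2ccco2)cc1` gives in an ADME assay on Raji cells (Homo sapiens) for cytotoxicity, read by CellTiter-Glo and resazurin assay, with a stated time of 72 h (a lower number here means that less compound is needed, a higher number that more compound is needed for the effect), only the limit > 26000 nM.
- compound 2 `COc1cccc(-c2ccc(C(=O)N(Cc3cccc(OCCCCCC(=O)O)c3)C(C)C)cc2)c1` gives in this assay only the limit > 20900 nM.
- compound 3 `CCOc1cccc(-c2ccc(C(=O)N(Cc3cccc(OCCCCCC(=O)O)c3)C(C)C)cc2)c1` gives in this assay only the limit > 20800 nM.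

None of the three measured compounds reaches a number in this assay. Compound 3 sits at its limit (the limit of > 20800 nM in this assay, at which 1 of the 3 values shown sits), and the two further values shown are limits as well (the limit of > 20900 nM in this assay, at which 1 of the 3 values shown sits, (the limit of > 26000 nM in this assay, at which 1 of the 3 values shown sits)). The steps a step that the two limits leave unreadable from compound 1 to compound 2, a step that the two limits leave unreadable from compound 1 to compound 3 and a step that the two limits leave unreadable from compound 2 to compound 3 are therefore all unreadable in size and direction. Compound 4 `CC(C)N(Cc1cccc(OCCCCCC(=O)O)c1)C(=O)c1ccc(-c2cccc(O)c2)cc1` has not been measured; it differs from compound 3 by hydrogen in place of ethyl on an oxygen on an aromatic ring. The most closely related measured step is a step that the two limits leave unreadable from compound 2 to compound 3, which also alters the chain attached to the aromatic oxygen, and its size could not be read. Going by the values given here, no measured step supplies a direction for the present change, so the expected step that the limit leaves unreadable from compound 3 to compound 4 is taken as none beyond the scatter. Compound 4 is thus expected to give 30000 nM in this assay, within 12000 nM to 90000 nM, most likely again reported only as a limit.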

Compound 4, half-maximal effective concentration: > 26000 nM
Compound 4: only a limit was reported (the forecaster's own chance of this, stated with the estimate: 85%); the middle value is on the limit's open side.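

Like compound 1, compound 2 and compound 3, compound 4 gives only a limit in this assay, and none of the steps to compound 4 can be read in size or direction. The compounds shown leave open what concentration any of them needs for the half-maximal effect, and whether these changes of group alter it.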